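The source may report more compounds than this note shows. Statements on the series, on what has been measured and on what is new or still open speak of the compounds shown alone.

For the measured compounds named here, compound 2, with the structure `COc1ccc(C(=O)O)cc1OCCCCOc1ccc(C(C)=O)c(O)c1C`, stands lowest of the two numbers measured so far in an assay on HEK293 cells for positive allosteric modulation of metabotropic glutamate receptor 2 (Rattus norvegicus), read by thallium flux, with a stated time of 2.5 min (on this read-out lower numbers stand for smaller maximal responses and higher numbers for larger maximal responses), where compound 2 gives 70.7%. Its nearest neighbour is compound 1, with the structure `COc1ccc(C(=O)O)cc1OCCCCOc1ccc(C(=O)CC2CCCC2)c(O)c1C`, which in this assay gives 91.8%. Going by the values given here, the one measured step between them, a number 21.1 percentage points lower from compound 1 to compound 2 (beyond the scatter), is a modest fall that lies beyond the scatter. Compound 3, with the structure `COc1ccc(C(=O)O)cc1OCCCCOc1ccc(C(=O)CC(C)C)c(O)c1C`, differs from compound 2 by isopropyl in place of hydrogen on a saturated chain carbon bound to a carbonyl carbon. This change bears on the same saturated chain carbon bound to a carbonyl carbon as the step from compound 1 to compound 2, and it adds carbon there rather than removing it, so a rise in this assay is expected for compound 3, reading the isopropyl as falling short of the cyclopentyl of compound 1 and giving a step of a number 13.3 percentage points higher from compound 2 to compound 3 (beyond the scatter). The estimated largest response of compound 3 in this assay is therefore 84%, within a range from 70% to 98%.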

Compound 3, largest response reached (reported as percent of maximum), in percent of the reference or control that the assay uses: 89.7%
For compound 3 the middle estimate is 5.7 percentage points below the measured one; low and high end bracket the measured number.
By their numbers in this assay, from the lowest: compound 2; then compounds 3 and 1 (each within the scatter of the next).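

In this assay, isopropyl in place of hydrogen gives a number 19 percentage points higher from compound 2 to compound 3 (beyond the scatter), so the fall seen on losing the cyclopentyl is not tied to that group alone: a group with no ring, at this saturated chain carbon bound to a carbonyl carbon, also gives a response beyond the scatter of that of compound 2. The exchange of cyclopentyl for isopropyl gives a number 2.1 percentage points lower from compound 1 to compound 3 (within the scatter), so these two groups cannot be told apart here. Nothing available accounts for this result.

From the compounds shown here alone, it remains open whether a single methyl at this place would already restore the response or would leave it nearer that of compound 2. Equally open, going by these compounds, is whether a phenyl group or an amine there would hold the response or lower it.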